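Swapping the nitro-bearing aryl on a fluoroquinolone-thiadiazole hybrid

The source may report more compounds than this note shows. Statements on the series, on what has been measured and on what is new or still open speak of the compounds shown alone.

Of the compounds shown here, three sharing one core have been measured in an ADME assay on NIH3T3 cells (Mus musculus) for cytotoxicity, read by MTT assay, with a stated time of 72 h; on this read-out lower numbers stand for stronger inhibition and higher numbers for weaker inhibition. Compound 1 `COc1c(N2CCN(c3nnc(-c4ccc([N+](=O)[O-])o4)s3)C(C)C2)c(F)cc2c(=O)c(C(=O)O)cn(C3CC3)c12` gives 238000 nM. Compound 2 `COc1c(N2CCN(c3nnc(-c4ccc([N+](=O)[O-])s4)s3)C(C)C2)c(F)cc2c(=O)c(C(=O)O)cn(C3CC3)c12` gives 243000 nM. Compound 3 `COc1c(N2CCN(c3nnc(-c4ncc([N+](=O)[O-])n4C)s3)C(C)C2)c(F)cc2c(=O)c(C(=O)O)cn(C3CC3)c12` gives 246000 nM. The three differ only in the aryl group carried on the thiadiazole, and the numbers do not separate: the step is a 1.0-fold higher number from compound 1 to compound 2 (0.01 log units; within the scatter), a 1.0-fold higher number from compound 1 to compound 3 (0.01 log units; within the scatter) and a 1.0-fold higher number from compound 2 to compound 3 (0.01 log units; within the scatter). Compound 3 therefore stands at the same level as compound 1 and compound 2, with no distinction beyond the scatter.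

Compound 4 `COc1c(N2CCN(c3nnc(-c4ccccc4[N+](=O)[O-])s3)C(C)C2)c(F)cc2c(=O)c(C(=O)O)cn(C3CC3)c12` takes the same route one step further: 2-nitrophenyl in place of 1-methyl-5-nitro-1H-imidazol-2-yl on an aromatic carbon. The three measured steps all bear on this change, since each exchanges one nitro-bearing aryl for another at the same position, and each came out within the scatter. On that basis the step from compound 3 to compound 4 in this assay is expected to be none beyond the scatter, in either direction. For compound 4 the expected value in this assay is 245000 nM, with a range from 120000 nM to 500000 nM. The estimate for compound 4 thus corresponds to a step of a 1.0-fold lower number from compound 3 to compound 4 (0.00 log units; within the scatter).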

Compound 4, half-maximal inhibitory concentration: 168000 nM
Compound 4: middle estimate off by 1.5-fold (0.16 log units), on the high side, within the range that was stated.
By their numbers in this assay, from the lowest: compounds 4, 1, 2 and 3 (each within the scatter of the next).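

Compound 4 brings the first six-membered aromatic ring of carbon only to this position, and in this assay the exchange stays within the scatter against all three five-membered aromatic rings: a 1.5-fold lower number from compound 3 to compound 4 (0.17 log units; within the scatter) and a 1.4-fold lower number from compound 2 to compound 4 (0.16 log units; within the scatter) and also a 1.4-fold lower number from compound 1 to compound 4 (0.15 log units; within the scatter) on the same read-out. Neither the size of the ring nor its hetero atoms therefore separate these compounds here, nor does the drop from 4 hydrogen-bond acceptors in the group leaving compound 3 to 2 in the 2-nitrophenyl group, and none of the four compounds goes against this. The data shown offer no measurement that would account for the four numbers staying so close together.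

From the compounds shown here alone, all four groups still carry a nitro group on an aromatic ring, so it remains open what a phenyl bearing an amine in place of the nitro group would give at this position. Whether a longer chain or a carboxylic acid on that aromatic carbon, in place of the aromatic ring, would move the number beyond the scatter is equally unanswered.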